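A few compounds are considered here, and "the series" means these few. Any claim that something is new, unique, unknown or untested is made for them only; others in the source may bear on it.

Compound 3 `CCCCCCCCc1ccc(OC(C)C(=O)Cn2nnc(-c3ccc(C(=O)OC)cc3)n2)cc1` is one of three measured members of the series. In a physicochemical assay for lipophilicity, read by HPLC, tested at 5 mM (on this read-out lower numbers stand for lower lipophilicity and higher numbers for higher lipophilicity), compound 3 returns only a limit, > 8. Compound 1 `CCCCCCCCc1ccc(OCC(=O)Cn2nnc(-c3ccc(C(=O)OC)cc3)n2)cc1` differs at the saturated chain carbon and in this assay gives 8. Compound 2 `CCCCCCCCc1ccc(OC(C)C(=O)Cn2nnc(-c3ccccc3)n2)cc1` lacks the methoxycarbonyl and in this assay also returns a limit, > 8. The two steps reaching compound 3 are therefore unreadable in size: a number no lower from compound 1 to compound 3 (the limit leaves the size open) and a step that the two limits leave unreadable from compound 2 to compound 3. Both limits sit at the limit of > 8 in this assay, at which 2 of the 3 values shown sit, so the series stands at the ceiling of the read-out.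

Compound 4 `COC(=O)c1ccc(-c2nnn(CC(=O)C(C)Oc3ccc(-c4ccccc4)cc3)n2)cc1` is not yet measured and differs from compound 3 by phenyl in place of octyl on an aromatic carbon. Within the data shown here, neither measured step touches this position; none of them exchanges the octyl chain, so no measured step bears directly on the change. Compound 4 is nevertheless expected to read somewhat lower than compound 3, the expected step being a number at least 0.70 log units lower from compound 3 to compound 4 (beyond the scatter). The estimate for compound 4 is 7.3, within 6.5 to 8.2, with a real chance that only a limit is reported.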

Compound 4, partition coefficient: 5.4
Compound 4: middle estimate off by 1.90 log units, on the high side; measured number outside the range, below it.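

In this assay, among these compounds, phenyl in place of octyl on an aromatic carbon gives a number at least 2.60 log units lower from compound 3 to compound 4 (beyond the scatter), the first step with a readable size, the earlier steps being unreadable. Among the compounds shown here, this position, on an aromatic carbon para to a large group, can therefore move the read-out by a large amount, which the earlier compounds could not show. The printed size is only a bound because compound 3 returns a limit, not a number: the limit of > 8 in this assay, at which 2 of the 4 values shown sit.

The compounds shown do not separate the loss of the octyl chain from the entry of the phenyl ring, and a butyl chain or a cyclohexyl ring on this aromatic carbon would bear on that. On these data alone, whether the step keeps its size without the methoxycarbonyl also stays open.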